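Swapping the hydrazone aryl: from hydroxy to dichloro

This account rests on a few compounds, and the source may have more. Where it says the series, first, only, none or still open, it means among the compounds named here.

Compound 1, `O=C(Cc1csc2nc(-c3ccc(Br)cc3)cn12)N/N=C/c1ccccc1`, gives 26900 nM in a functional assay on SK-MEL-5 cells (Homo sapiens) for inhibition, read by sulforhodamine B assay, with a stated time of 48 h; on this read-out lower numbers stand for stronger inhibition of growth and higher numbers for weaker inhibition of growth.
Compound 2, `O=C(Cc1csc2nc(-c3ccc(Br)cc3)cn12)N/N=C/c1ccccc1O`, gives 10700 nM.
Compound 3, `O=C(Cc1csc2nc(-c3ccc(Br)cc3)cn12)N/N=C/c1ccc(O)cc1`, gives 22400 nM.

Among these three numbers compound 3 stands second highest. Its nearest neighbour is compound 1, and the step of a 1.2-fold lower number from compound 1 to compound 3 (0.08 log units; within the scatter) lies within the scatter, so these two cannot be told apart. Its furthest neighbour is compound 2, and the step of a 2.1-fold higher number from compound 2 to compound 3 (0.32 log units; beyond the scatter) is modest but beyond the scatter. Among the measured compounds shown here, the only other measured step, a 2.5-fold lower number from compound 1 to compound 2 (0.40 log units; beyond the scatter), is of similar size.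

Compound 4, `O=C(Cc1csc2nc(-c3ccc(Br)cc3)cn12)N/N=C/c1ccc(Cl)cc1Cl`, has not yet been measured. The change from compound 3 is 2,4-dichlorophenyl in place of 4-hydroxyphenyl on a carbon with a double bond to nitrogen. None of the three measured steps involves chlorine on this ring, so no direct guide exists. The steps that come closest are those that add or move a hydroxy on the same ring: one of them, a 1.2-fold lower number from compound 1 to compound 3 (0.08 log units; within the scatter), changed nothing beyond the scatter, and the other two were modest. On that basis a step of no more than modest size is expected in this assay, with the direction uncertain. The estimated step is a 1.1-fold lower number from compound 3 to compound 4 (0.05 log units; within the scatter), giving for compound 4 an expected value of 20000 nM with a range from 7000 nM to 55000 nM.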

Compound 4, concentration for total growth inhibition: > 100000 nM
Compound 4 ended at the assay's limit; the forecaster's own chance of this, stated with the estimate: 10%; at least 5.0-fold (0.69 log units) between middle value and limit.
By their numbers in this assay, from the lowest: compound 2; then compounds 3 and 1 (each within the scatter of the next). At a limit, above all of these: compound 4.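

In this assay, compound 4 sits at a limit of the assay, which is not a number: the limit of > 100000 nM in this assay, at which 1 of the 4 values shown sits. The change to 2,4-dichlorophenyl on the carbon with a double bond to nitrogen brings an at least 4.4-fold higher number from compound 3 to compound 4 (0.64 log units; beyond the scatter), an at least 9.3-fold higher number from compound 2 to compound 4 (0.97 log units; beyond the scatter) and an at least 3.7-fold higher number from compound 1 to compound 4 (0.57 log units; beyond the scatter), so this position, where swapping or adding a hydroxy had produced only modest steps or none beyond the scatter, can also carry a group that moves the read-out much further toward weaker inhibition of growth. The loss of the hydroxy alone does not describe this change, since compound 1 also has no hydroxy on this ring and still stands apart from compound 4.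

The compounds shown leave open whether a single chlorine on this ring would be enough for such a step, or whether both chlorines are needed. From the compounds shown here alone, they also leave open how a methoxy group or an amine on the same ring would compare, and the full size of all three steps stays unknown while compound 4 rests at a limit.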